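A few compounds are considered here, and "the series" means these few. Any claim that something is new, unique, unknown or untested is made for them only; others in the source may bear on it.

Three compounds have been measured in a functional assay on the whole organism for inhibition, with Nicotiana tabacum as the target; a higher number here means a weaker inhibitor, a lower number a stronger inhibitor:

Compound 1, `Cc1nc(Nc2ccc(Br)cc2)c2cc[nH]c2n1`: 170000000 nM
Compound 2, `Cc1nc(Nc2ccc(O)cc2)c2cc[nH]c2n1`: 155000000 nM
Compound 3, `CCCNc1[nH]c(C)nc2nccc1-2`: 339000000 nM

Compound 3 is built on a different core from the other two, carrying a propylamino chain rather than an anilino group. Its number sits within the scatter of compound 1, so no order can be read between those two, while its gap to compound 2 lies beyond the scatter.

Compound 4, `COCCNc1[nH]c(C)nc2nccc1-2`, is not yet measured. It differs from compound 3 in one place: methoxy in place of methyl on a saturated chain carbon, two bonds along the chain from a nitrogen on an aromatic ring. Among the compounds with values here, the only measured step in this set, a 1.1-fold lower number from compound 1 to compound 2 (0.04 log units; within the scatter), concerns a substituent on an aromatic carbon of the anilino series and therefore does not touch the saturated chain that is changed here; it also stayed within the scatter. Within the data shown here, no measured pair shows what a methoxy in place of a methyl on such a chain does. On the evidence at hand the account therefore expects no step beyond the scatter, a 1.0-fold higher number from compound 3 to compound 4 (0.00 log units; within the scatter), from compound 3 to compound 4 in this assay. Compound 4 is estimated at 340000000 nM, with a range from 150000000 nM to 750000000 nM.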

Compound 4, half-maximal inhibitory concentration: 166000000 nM
Compound 4: the middle estimate sits 2.0-fold (0.31 log units) above what was measured, within the range that was stated.
By their numbers in this assay, from the lowest: compounds 2, 4, 1 and 3 (each within the scatter of the next, the first and the last beyond it).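

In this assay, the saturated chain responds to this change: methoxy in place of methyl on a saturated chain carbon, two bonds along the chain from a nitrogen on an aromatic ring, gives a 2.0-fold lower number from compound 3 to compound 4 (0.31 log units; beyond the scatter), a modest step towards stronger inhibition. Within the data shown here, the only earlier step between compounds differing in one place, a 1.1-fold lower number from compound 1 to compound 2 (0.04 log units; within the scatter), concerned an aromatic carbon and stayed within the scatter, so this chain is the first place in the set where a single change moves the number beyond it. The step is small and rests on one pair of compounds, and no measurement shown here bears on why the number moved.

The swap adds both a heavy atom and an oxygen, and the compounds shown cannot separate the two, which a butyl chain on the same nitrogen would begin to do. Also open, as far as these compounds go, are how a hydroxy group or an amine at the end of this chain would read, and whether a longer chain carrying the methoxy would go further or give the step back.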